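Trimming the carbamate ester: from a branched to a shorter fluorinated chain

A few compounds are considered here, and "the series" means these few. Any claim that something is new, unique, unknown or untested is made for them only; others in the source may bear on it.

The measured compounds and their values in a functional assay on isolated protein for inhibition of Glucose-dependent insulinotropic receptor (Rattus norvegicus), read by HTRF and cAMP accumulation (a higher number here means a larger maximal response, a lower number a smaller maximal response), are:
compound 1, `Cc1nc(S(C)(=O)=O)ccc1Oc1ncnc(OC2CCN(C(=O)OC(C)C)CC2)c1F`, gives 77%;
compound 2, `Cc1nc(S(C)(=O)=O)ccc1Oc1ncnc(OC2CCN(C(=O)OC(C)(C)C#N)CC2)c1F`, gives 97%;
compound 3, `Cc1nc(S(C)(=O)=O)ccc1Oc1ncnc(OC2CCN(C(=O)OC(C)(C)CF)CC2)c1F`, gives 95%.

Compound 3 stands second highest of the three numbers. Its nearest neighbour is compound 2, where the difference is a number 2 percentage points lower from compound 2 to compound 3 (within the scatter). Its furthest neighbour is compound 1, where the step is a number 18 percentage points higher from compound 1 to compound 3 (beyond the scatter).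

Compound 4, `Cc1nc(S(C)(=O)=O)ccc1Oc1ncnc(OC2CCN(C(=O)O[C@H](C)CF)CC2)c1F`, is the next compound to be measured. Compared with compound 3 the change is 1-(fluoromethyl)ethyl in place of 1-(fluoromethyl)-1-methylethyl on an oxygen next to a carbonyl group. The fluoromethyl that distinguishes compound 3 from compound 1 is kept, but one methyl on the same chain carbon is removed, and a stereocentre is introduced.

For the measured compounds named here, the steps that bear on this are the two that added a group to the chain carbon of compound 1: a number 20 percentage points higher from compound 1 to compound 2 (beyond the scatter) and a number 18 percentage points higher from compound 1 to compound 3 (beyond the scatter), both modest and beyond the scatter, while the swap between those two groups, a number 2 percentage points lower from compound 2 to compound 3 (within the scatter), lay within the scatter. Going by the values given here, no measured step removes a methyl from this carbon, so the data give no direct guide to that part of the change. Since the fluoromethyl is retained, compound 4 is expected to stay nearer compound 3 than compound 1, with a step of a number 5 percentage points lower from compound 3 to compound 4 (within the scatter) that is expected to be small and possibly within the scatter. Compound 4 is estimated at 90%, with a range from 78% to 100%.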

Compound 4, largest response reached (reported as efficacy), in percent of the reference or control that the assay uses: 79%
Beside the measured number, compound 4's estimate is 11 percentage points above it; low and high end bracket the measured number.
By their numbers in this assay, from the lowest: compounds 1 and 4 (each within the scatter of the next); then compounds 3 and 2 (each within the scatter of the next).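

In this assay, removing one methyl from the chain carbon costs more than the retained fluoromethyl can hold: there is a number 16 percentage points lower from compound 3 to compound 4 (beyond the scatter) for that single change, and a number 18 percentage points lower from compound 2 to compound 4 (beyond the scatter) against the 1-cyano-1-methylethyl ester. Fluorine alone adds little to the ester of compound 1, with a number 2 percentage points higher from compound 1 to compound 4 (within the scatter) for the 1-(fluoromethyl)ethyl group, so among these compounds the higher responses belong only to the two esters with a fully substituted chain carbon. The compounds shown offer no measurement that explains this dependence on the methyl.

They leave open whether the opposite configuration at the new stereocentre would give a different response. As far as these compounds go, it is also open whether a trifluoromethyl in place of the fluoromethyl, on either the branched or the shorter chain, would keep the response of compound 3.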